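A few compounds are considered here, and "the series" means these few. Any claim that something is new, unique, unknown or untested is made for them only; others in the source may bear on it.

Measured so far in a functional assay on MCF7 cells (Homo sapiens) for inhibition, read by MTT assay, with a stated time of 48 h; on this read-out lower numbers stand for stronger inhibition of growth and higher numbers for weaker inhibition of growth:
compound 1 `Cn1cc(C2CC(c3ccccc3)=NN2C(=O)c2cccnc2)c2ccccc21` — 7200 nM
compound 2 `Cn1cc(C2CC(c3ccccc3)=NN2C(=O)c2ccncc2)c2ccccc21` — 1110 nM
compound 3 `COc1ccc(C2=NN(C(=O)c3cccnc3)C(c3cn(C)c4ccc(Br)cc34)C2)cc1OC` — 1170 nM

Compounds 1 and 2 share one core and differ in a single place: pyridin-4-yl in place of pyridin-3-yl on a carbonyl carbon. That step gave a 6.5-fold lower number from compound 1 to compound 2 (0.81 log units; beyond the scatter). Compound 3 carries a second core; the difference between the two cores is not broken down here. In this assay compound 3 stands within the scatter of compound 2, and against compound 1 it shows the lower number.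

Compound 4 `COc1ccc(C2=NN(C(=O)c3ccncc3)C(c3cn(C)c4ccc(Br)cc34)C2)cc1OC` has not yet been measured. It differs from compound 3 by pyridin-4-yl in place of pyridin-3-yl on a carbonyl carbon. The place of the change is the same word for word as in the pair of compound 1 and compound 2, so this is the same change, carried over to the second core.

Expectation: the single precedent, the step from compound 1 to compound 2 with a 6.5-fold lower number from compound 1 to compound 2 (0.81 log units; beyond the scatter), points toward a lower number for compound 4 than for compound 3. Because a 6.5-fold lower number from compound 1 to compound 2 (0.81 log units; beyond the scatter) rests on one pair and on a different core, the step is expected to be weaker than that precedent, and an estimated step of a 3.3-fold lower number from compound 3 to compound 4 (0.52 log units; beyond the scatter) is set for compound 3 to compound 4. Compound 4 is expected to give 350 nM in this assay, with the estimate ranging from 120 nM to 1000 nM.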

Compound 4, concentration for 50% growth inhibition: > 10000 nM
Compound 4 was reported as a limit; the forecaster's own chance of this, stated with the estimate: 3%; middle value at least 28-fold (1.45 log units) from the limit.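

In this assay compound 4 is reported as > 10000 nM, which is a limit of the assay and not a number: the limit of > 10000 nM in this assay, at which 1 of the 4 values shown sits. Carrying pyridin-4-yl in place of pyridin-3-yl on a carbonyl carbon over to the second core gives an at least 8.5-fold higher number from compound 3 to compound 4 (0.93 log units; beyond the scatter), so the step does not keep its direction from one core to the other: the same change on two cores in this assay, a 6.5-fold lower number (0.81 log units; beyond the scatter) from compound 1 to compound 2 and an at least 8.5-fold higher number (0.93 log units; beyond the scatter) from compound 3 to compound 4, at least 55-fold (1.74 log units) apart, beyond the scatter of two such steps. As far as these compounds go, this rests on one pair per core; it shows that the effect of this change cannot be transferred between these two cores, but it does not show which difference between the cores turns the step round, and the true size of the step on the second core remains unknown.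

From the compounds shown here alone, it remains open whether a core carrying only the bromine or only the two methoxy groups would follow the pair of compound 1 and compound 2 or the pair of compound 3 and compound 4. Also open, going by these compounds, is how either core would respond if the pyridine ring on the carbonyl carbon gave way to a phenyl ring bearing a primary amine or a carboxylic acid.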